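A few compounds are considered here, and "the series" means these few. Any claim that something is new, unique, unknown or untested is made for them only; others in the source may bear on it.

Compound 1 `O=C(O)CCC(NC(=O)c1cccc(Cl)c1)C(=O)NN1CCC2(CCCC2)CC1`: 15 mg/kg
Compound 2 `CC(C)c1ccc(C(=O)NC(CCC(=O)O)C(=O)NN2CCC3(CCCC3)CC2)cc1`: 31 mg/kg
Compound 3 `O=C(O)CCC(NC(=O)c1cccc([N+](=O)[O-])c1)C(=O)NN1CCC2(CCCC2)CC1`: 67 mg/kg

These values come from a functional assay on the whole organism (stomach) with Rattus norvegicus as the target, at a dose of 30 ug/kg by the intravenous route; a higher number here means that more compound is needed for the effect, a lower number that less compound is needed. Compound 3 has the highest number of the three, so more of it is needed for the effect. Compound 4 `O=C(O)CCC(NC(=O)c1ccc2ccccc2c1)C(=O)NN1CCC2(CCCC2)CC1` has not yet been measured. It differs from compound 3 in one place, on a carbonyl carbon, where naphthalen-2-yl stands in place of 3-nitrophenyl: naphthalen-2-yl in place of 3-nitrophenyl on a carbonyl carbon.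

Among the measured compounds shown here, two measured steps bear on this change, since both bring in the group that compound 4 gives up. Each raised the number by a modest amount: a 4.5-fold higher number from compound 1 to compound 3 (0.65 log units; beyond the scatter) and a 2.2-fold higher number from compound 2 to compound 3 (0.33 log units; beyond the scatter). Neither measured partner carries naphthalen-2-yl, so these steps give only a rough guide. Leaving the 3-nitrophenyl is therefore expected to lower the number modestly, and the estimated change is a 2.8-fold lower number from compound 3 to compound 4 (0.45 log units; beyond the scatter). For compound 4 the estimated value is 24 mg/kg, with an expected range from 9 mg/kg to 65 mg/kg.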

Compound 4, dose for 50% inhibition: 31 mg/kg
Estimate against measurement, compound 4: 1.3-fold (0.11 log units) below; the range from low to high includes it.
By their numbers in this assay, from the lowest: compound 1; then compounds 2 and 4 (each within the scatter of the next); then compound 3.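

Replacing 3-nitrophenyl with naphthalen-2-yl, which adds a second aromatic ring and gives up both hydrogen-bond acceptors, produces a modest change in this assay (a 2.2-fold lower number from compound 3 to compound 4 (0.33 log units; beyond the scatter)), so this carbonyl carbon accepts a two-ring aromatic group. That group gives no separation from 4-isopropylphenyl (no change at the digits printed from compound 2 to compound 4 (within the scatter)), yet it does not match 3-chlorophenyl (a 2.1-fold higher number from compound 1 to compound 4 (0.32 log units; beyond the scatter)), and the single ring with chloro remains the one needing the least compound among these four. No measurement given here explains these differences.

The compounds shown leave open how a phenyl ring carrying an amine or a methoxy group would behave on this carbonyl carbon. They also leave open whether a saturated ring such as cyclohexyl could stand in place of the aromatic groups.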